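The source may hold more compounds than are shown below. What is called first, only, known or untested is meant among the compounds shown, and "the series" means these compounds.

Three compounds sharing one core were examined in a functional assay on MDA-MB-435 cells (Homo sapiens) for antiproliferative activity, read by sulforhodamine B assay, with a stated time of 72 h; a lower number here means a stronger inhibitor, a higher number a weaker inhibitor. Compound 1 `Cc1cc(NS(=O)(=O)c2ccc(Nc3nncc4ccccc34)cc2)no1` gives 27 nM in this assay. Compound 2 `COc1ccc(NC(=S)NNc2nncc3ccccc23)cc1` gives 88 nM in this assay, and compound 3 `C(=C/c1ccccc1)\C(=N\Nc1nncc2ccccc12)c1ccccc1` gives 3 nM in this assay. Compound 1 thus stands second highest of the three, its number lying above that of compound 3 and below that of compound 2, and both gaps lie beyond the usual scatter. Compound 4 `Cc1cc(C)nc(NS(=O)(=O)c2ccc(Nc3nncc4ccccc34)cc2)n1` has not yet been measured. It differs from compound 1 by 4,6-dimethylpyrimidin-2-yl in place of 5-methyl-1,2-oxazol-3-yl on a sulfonamide nitrogen. Going by the values given here, no measured pair shows this change, and its size is therefore unknown from the data. The step of a 1.3-fold higher number from compound 1 to compound 4 (0.11 log units; within the scatter) is expected to be small, with no firm direction. The estimate for compound 4 in this assay is 35 nM, with a range from 10 nM to 120 nM.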

Compound 4, half-maximal inhibitory concentration: 3.4 nM
Estimate against measurement, compound 4: 10-fold (1.01 log units) above; the whole stated range lies above it.
By their numbers in this assay, from the lowest: compounds 3 and 4 (each within the scatter of the next); then compound 1; then compound 2.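

The sulfonamide nitrogen is a place where the attached ring counts: in this assay, 4,6-dimethylpyrimidin-2-yl in place of 5-methyl-1,2-oxazol-3-yl gives a 7.9-fold lower number from compound 1 to compound 4 (0.90 log units; beyond the scatter), a step beyond the scatter. The earlier compounds shown here could not show this, as no two of them differed in one place. No measurement at hand bears on this step. As far as these compounds go, whether the change depends on the six-membered ring or on its two methyl groups remains open. Also open, from the compounds shown here alone, is how a pyrimidin-2-yl without methyl groups, or a plain phenyl, would behave on the same nitrogen.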